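Dropping a Bromine from an Indole Hydrazone

The compounds below may be only part of what the source reports. "The series", "measured", "known", "first", "only" and "open" are said of these compounds alone.

Of the compounds shown here, two have been measured so far. Compound 1 `COc1ccc(Cn2cc(/C=N\NC(=O)c3c[nH]c4ccccc34)c3ccccc32)cc1` carries a methoxybenzyl group on its core; in a functional assay on MIA PaCa-2 cells (Homo sapiens) for cytotoxicity (on this read-out higher numbers stand for weaker inhibition and lower numbers for stronger inhibition), compound 1 gives 41600 nM. Compound 2 `O=C(N/N=C\c1cn(Cc2ccc(Cl)cc2)c2ccc(Br)cc12)c1c[nH]c2ccccc12` carries a chlorobenzyl group and a bromo group; in this assay compound 2 gives 8700 nM, the lower of the two numbers, and its gap to compound 1 lies beyond the usual scatter of repeated measurements. Compound 3 `O=C(N/N=C\c1cn(Cc2ccc(Cl)cc2)c2ccccc12)c1c[nH]c2ccccc12` has not been measured. It differs from compound 2 in one place only: hydrogen in place of bromo on an aromatic carbon. Going by the values given here, no pair of measured compounds shows this change by itself, and compound 1 differs from compound 3 elsewhere as well, so the data give no direct guide. In this assay the expected step is a 2.1-fold higher number from compound 2 to compound 3 (0.32 log units; beyond the scatter), a modest loss of strength. For compound 3 the estimated value in this assay is 18000 nM, expected to fall between 7000 nM and 45000 nM.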

Compound 3, half-maximal inhibitory concentration: 44300 nM
For compound 3 the middle estimate is 2.5-fold (0.39 log units) below the measured one; measured number inside the range.
By their numbers in this assay, from the lowest: compound 2; then compounds 1 and 3 (each within the scatter of the next).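

In this assay, a single bromine atom on this aromatic carbon matters: with hydrogen in its place, the read-out shows a clear loss of strength (a 5.1-fold higher number from compound 2 to compound 3 (0.71 log units; beyond the scatter)). Without the bromo, the other change on the benzyl group can't be told apart from noise, as chloro in place of methoxy leaves the two compounds level (a 1.1-fold higher number from compound 1 to compound 3 (0.03 log units; within the scatter)). Nothing at hand explains why the bromo makes this difference.

From the compounds shown here alone, it remains open whether the gain is specific to bromine or whether another group on the same carbon, such as fluoro, methyl or a nitrile, would give it too. Going by these compounds, it is also open whether chloro and methoxy on the benzyl group would stay level with the bromo present.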